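The compounds below may be only part of what the source reports. "The series", "measured", "known", "first", "only" and "open" are said of these compounds alone.

Values in a functional assay on MCF7 cells (Homo sapiens) for inhibition, read by sulforhodamine B assay (a lower number here means a stronger inhibitor, a higher number a weaker inhibitor), as measured:
compound 1 `COc1ccccc1NC1=CC(=O)c2c(nc3n2[C@H]2OC[C@@H](O)[C@H]2OC3)C1=O`: 6580 nM
compound 2 `O=C1C(Nc2ccc(C(F)(F)F)cc2)=CC(=O)c2c1nc1n2[C@H]2OC[C@@H](O)[C@H]2OC1`: > 4000 nM (a limit)
compound 3 `O=C1C(NC2CCCCC2)=CC(=O)c2c1nc1n2[C@H]2OC[C@@H](O)[C@H]2OC1`: > 16000 nM (a limit)

Compound 3 has only the limit > 16000 nM and so no exact place in the series. Compound 4 `O=C1C(Nc2cccc(Cl)c2)=CC(=O)c2c1nc1n2[C@H]2OC[C@@H](O)[C@H]2OC1` differs from it by 3-chlorophenyl in place of cyclohexyl on an amine nitrogen. Among the compounds with values here, only one relevant step has a readable size: an at least 2.4-fold higher number from compound 1 to compound 3 (0.38 log units; beyond the scatter). The steps a step that the limit leaves unreadable from compound 1 to compound 2 and a step that the two limits leave unreadable from compound 2 to compound 3 give no size. Reversing the direction of the step to compound 3, a move to a lower number in this assay is expected, of at least modest size. The expected step is an at least 2.6-fold lower number from compound 3 to compound 4 (0.42 log units; beyond the scatter). For compound 4 the estimated value is 6000 nM, with an expected range of 2000 nM to 18000 nM.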

Compound 4, half-maximal inhibitory concentration: 2970 nM
For compound 4 the middle estimate is 2.0-fold (0.31 log units) above the measured one, and the stated range covers the measured number.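

On this amine nitrogen, this assay now gives a pair of aryl groups with exact values: 3-chlorophenyl in place of 2-methoxyphenyl is a 2.2-fold lower number from compound 1 to compound 4 (0.35 log units; beyond the scatter). Swapping cyclohexyl for 3-chlorophenyl is an at least 5.3-fold lower number from compound 3 to compound 4 (0.73 log units; beyond the scatter), which sets an aromatic ring apart from a saturated one here, on this single pair. Against 4-(trifluoromethyl)phenyl the result is an at least 1.3-fold lower number from compound 2 to compound 4 (0.12 log units; that floor lies within the scatter), so no order between these two aryl groups can be drawn.

As far as these compounds go, whether the lower number depends on the chlorine itself or on where it sits stays open. Also open, from the compounds shown here alone, is how an aminoalkyl chain or a carboxylic acid on the aryl ring would read.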